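From a fluorophenyl urea to a chlorophenyl urea

This account rests on a few compounds, and the source may have more. Where it says the series, first, only, none or still open, it means among the compounds named here.

Compound 3 `COc1cc(NC(C)CCCNC(=O)Nc2cccc(F)c2)c2ncccc2c1` gives the lowest of three numbers in a functional assay on MOLT-4 cells (Homo sapiens) for inhibition, read by MTT assay, with a stated time of 72 h (a higher number here means a weaker inhibitor, a lower number a stronger inhibitor), at 23000 nM. Compound 1 `COc1cc(NC(C)CCCNC(=O)NNC(=O)Nc2ccc(Br)cc2)c2ncccc2c1` gives 209000 nM and compound 2 `COc1cc(NC(C)CCCNC(=O)NNC(=O)Nc2ccc(O)cc2)c2ncccc2c1` gives 104000 nM. The steps of a 9.1-fold lower number from compound 1 to compound 3 (0.96 log units; beyond the scatter) and a 4.5-fold lower number from compound 2 to compound 3 (0.66 log units; beyond the scatter) both rebuild the chain that carries the phenyl group, whereas a 2.0-fold lower number from compound 1 to compound 2 (0.30 log units; within the scatter) only exchanges one group on that phenyl for another. Compound 4 `COc1cc(NC(C)CCCNC(=O)Nc2ccc(Cl)cc2)c2ncccc2c1` differs from compound 3 solely in the phenyl group: 4-chlorophenyl in place of 3-fluorophenyl on an amide-type nitrogen. Among the measured compounds shown here, no measured step exchanges one substituted phenyl for another in this shorter urea chain, and the one phenyl exchange that was measured, between compound 1 and compound 2, stayed within the scatter. The expected step for compound 4 is therefore a 1.2-fold lower number from compound 3 to compound 4 (0.06 log units; within the scatter), within the scatter. Compound 4 is estimated at 20000 nM, ranging from 7000 nM to 60000 nM.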

Compound 4, half-maximal inhibitory concentration: 24000 nM
Compound 4: middle estimate off by 1.2-fold (0.08 log units), on the low side; the range from low to high includes it.
By their numbers in this assay, from the lowest: compounds 3 and 4 (each within the scatter of the next); then compounds 2 and 1 (each within the scatter of the next).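

In this assay, among the compounds shown here, this is the first exchange of one substituted phenyl for another on the amide-type nitrogen of the shorter urea chain, and a 1.0-fold higher number from compound 3 to compound 4 (0.02 log units; within the scatter) shows that 4-chlorophenyl and 3-fluorophenyl cannot be told apart here. Both a 4.3-fold lower number from compound 2 to compound 4 (0.64 log units; beyond the scatter) and an 8.7-fold lower number from compound 1 to compound 4 (0.94 log units; beyond the scatter) lie beyond the scatter, so the lower numbers of the shorter urea chain hold with a second phenyl group. Nothing measured here gives a reason for these numbers.

Going by these compounds, whether a phenyl carrying an amine or a carboxylic acid would shift the number remains open. So does the effect of a longer chain in place of the one that carries the urea.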